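The compounds below may be only part of what the source reports. "The series", "measured", "known", "first", "only" and "open" are said of these compounds alone.

Measured compounds in a functional assay on MCF7 cells (Homo sapiens) for antiproliferative activity, read by MTT assay, with a stated time of 48 h; a higher number here means a weaker inhibitor, a lower number a stronger inhibitor:
- compound 1, `N#CC1=C(N)Oc2c(c3nc4ccccc4nc3c3ccccc23)C12C(=O)N(Cc1cnnn1-c1ccccc1Cl)c1ccccc12`: in this assay compound 1 gives > 50000 nM, which is a limit of the assay and not a number.
- compound 2, `N#CC1=C(N)Oc2c(c3nc4ccccc4nc3c3ccccc23)C12C(=O)N(Cc1cnnn1-c1cccc(Cl)c1)c1ccccc12`: in this assay compound 2 gives 43600 nM.

Within the data shown here, compound 2 carries the only numerical value in this assay; the other entry is a limit (the limit of > 50000 nM in this assay, at which 1 of the 2 values shown sits). Among the measured compounds shown here, the single measured step, an at least 1.1-fold lower number from compound 1 to compound 2 (0.05 log units; that floor lies within the scatter), therefore runs from a limit to a number, and its floor lies within the scatter, so the exchange of 2-chlorophenyl for 3-chlorophenyl on the aromatic nitrogen shows no change that can be separated from noise.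

Compound 3, `N#CC1=C(N)Oc2c(c3nc4ccccc4nc3c3ccccc23)C12C(=O)N(Cc1cnnn1-c1cccc(Br)c1)c1ccccc12`, differs from compound 2 by bromo in place of chloro on an aromatic carbon. For the measured compounds named here, no measured step exchanges one halogen for another at this carbon; the only step available concerns the chloro pattern on the same ring and sits within the scatter. The change from compound 2 to compound 3 is thus expected to yield no step beyond the scatter in this assay, a 1.1-fold lower number from compound 2 to compound 3 (0.04 log units; within the scatter). For compound 3 the expected value is 40000 nM, in a range from 15000 nM to 100000 nM, with a fair chance that the assay returns only a limit.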

Compound 3, half-maximal inhibitory concentration: > 50000 nM
Compound 3: no number, only a limit; the forecaster's own chance of this, stated with the estimate: 40%; middle value at least 1.2-fold (0.09 log units) away from the limit.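

Bromo in place of chloro on this aromatic carbon gives an at least 1.1-fold higher number from compound 2 to compound 3 (0.05 log units; that floor lies within the scatter), so the first halogen exchange at this position in this assay shows no change that can be separated from noise. In this assay compound 3 gives > 50000 nM, which is a limit of the assay and not a number. The step between compound 1 and compound 3 cannot be read, and the series now rests mostly on a single limit: the limit of > 50000 nM in this assay, at which 2 of the 3 values shown sit.

Compound 2 gives 43600 nM, the only number in this assay, so the compounds shown give no reference point for a clear gain or loss, and nothing shows whether the 3-position of this phenyl ring can move the number at all. Chloro and bromo are the only groups shown on this ring, which leaves open how an amine, a carboxylic acid or a longer chain at the same carbon would read out against the same limit.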